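Cyclohexyl for Ethyl on the Hydroxyurea Nitrogen

The source may report more compounds than this note shows. Statements on the series, on what has been measured and on what is new or still open speak of the compounds shown alone.

Measured compounds:
compound 1, `Cc1nc(-c2c(Cl)cc(Cl)cc2-c2cnc([C@@H](C)NC(=O)N(C)O)c(F)c2)no1`, 2.3 nM
compound 2, `CCN(O)C(=O)NCc1ncc(-c2cc(Cl)cc(F)c2-c2nnn(C)n2)cc1F`, 4.6 nM

Two compounds have numbers in a functional assay on IMR-90 cells for antagonist activity at B1 bradykinin receptor (Homo sapiens), read by calcium flux; on this read-out higher numbers stand for weaker inhibition and lower numbers for stronger inhibition. Compound 1 gives 2.3 nM in this assay. Compound 2 gives 4.6 nM in this assay, the higher of the two numbers; its nearest neighbour is compound 1, and the gap between the two lies within the scatter, so no order between them can be claimed. The two compounds differ in several places at once, so no single step can be read from the pair.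

Compound 3, `Cn1nnc(-c2c(F)cc(Cl)cc2-c2cnc(CNC(=O)N(O)C3CCCCC3)c(F)c2)n1`, has not been measured in this assay. It differs from compound 2 in one place: cyclohexyl in place of ethyl on an amide-type nitrogen. Among the measured compounds shown here, no pair of measured compounds shows this change, so there is nothing in the data to say what size of step in this assay it brings. Compound 3 is therefore expected to stay close to the number of compound 2, with a step of a 1.3-fold higher number from compound 2 to compound 3 (0.12 log units; within the scatter) that may fall either side of no change. For compound 3 the estimate in this assay is 6 nM, expected between 1.5 nM and 25 nM.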

Compound 3, half-maximal inhibitory concentration: 3.9 nM
Compound 3: the middle estimate sits 1.5-fold (0.19 log units) above what was measured; low and high end bracket the measured number.
By their numbers in this assay, from the lowest: compounds 1, 3 and 2 (each within the scatter of the next).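

In this assay, among the compounds shown here, the step from ethyl to cyclohexyl on the amide-type nitrogen whose other neighbours are the carbonyl carbon and the oxygen is a 1.2-fold lower number from compound 2 to compound 3 (0.07 log units; within the scatter) and gives the first reading of a single change at this position. It shows that the 2 heavy atoms of ethyl can give way to the 6 heavy atoms of cyclohexyl, with its six-membered non-aromatic ring of carbon only, and the number of compound 3 remains within the scatter of that of compound 2. The data offer no explanation for this outcome, and no other measurement bears on it.

The compounds shown leave open whether a longer chain, a phenyl ring or a chain ending in an amine on this nitrogen would also remain within the scatter of compound 2, since a single replacement cannot mark the limits of what this position tolerates. They also leave open whether cyclohexyl would give a similar step on the core of compound 1, and whether a methoxy group could take the place of the hydroxy group on the same nitrogen.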